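Hydroxamate series: bromo to methoxy swap on the fused ring

The source may report more compounds than this note shows. Statements on the series, on what has been measured and on what is new or still open speak of the compounds shown alone.

Three compounds carry a hydroxamic acid on a benzyl arm and differ in two places. Compound 2 `O=C(/C=C/c1ccc(CN2C(=O)/C(=C3\Nc4ccccc4\C3=N/O)c3cc(Br)ccc32)cc1)NO` gives 9 nM in a functional assay on NCI-H23 cells (Homo sapiens) for cytotoxicity, read by colorimetric assay; a lower number here means a stronger inhibitor, a higher number a weaker inhibitor. Compound 3 `O=C(NO)c1ccc(CN2C(=O)/C(=C3\Nc4ccccc4\C3=N/O)c3cc(Br)ccc32)cc1` gives 7 nM; its difference from compound 2 is hydroxycarbamoyl in place of 2-(hydroxycarbamoyl)ethenyl on an aromatic carbon, and the step is a 1.3-fold lower number from compound 2 to compound 3 (0.11 log units; within the scatter). Compound 1 `COc1ccc2c(c1)/C(=C1/Nc3ccccc3/C1=N\O)C(=O)N2Cc1ccc(/C=C/C(=O)NO)cc1` gives 50 nM; it differs from compound 2 by methoxy in place of bromo on an aromatic carbon, and the step is a 5.6-fold higher number from compound 2 to compound 1 (0.74 log units; beyond the scatter).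

Compound 4 `COc1ccc2c(c1)/C(=C1/Nc3ccccc3/C1=N\O)C(=O)N2Cc1ccc(C(=O)NO)cc1` has not been measured. Its difference from compound 3 is methoxy in place of bromo on an aromatic carbon, which is the same change already seen from compound 2 to compound 1, at the same place. The two cores differ as described above for compound 2 against compound 3.

The change is seen once among the measured pairs, so the expectation leans on that single step. For the measured compounds named here, for compound 4 a step of about a 5.7-fold higher number from compound 3 to compound 4 (0.76 log units; beyond the scatter) is expected in this assay because a 5.6-fold higher number from compound 2 to compound 1 (0.74 log units; beyond the scatter) sets the size of the only precedent. Compound 4 is therefore estimated at 40 nM, with a range from 15 nM to 110 nM.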

Compound 4, half-maximal inhibitory concentration: 90 nM
For compound 4 the middle estimate is 2.3-fold (0.35 log units) below the measured one; low and high end bracket the measured number.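

In this assay methoxy in place of bromo again gives a weaker inhibitor on the hydroxycarbamoyl core (a 13-fold higher number from compound 3 to compound 4 (1.11 log units; beyond the scatter)), and the two readings of this change agree: the same change on two cores in this assay, a 5.6-fold higher number (0.74 log units; beyond the scatter) from compound 2 to compound 1 and a 13-fold higher number (1.11 log units; beyond the scatter) from compound 3 to compound 4, 2.3-fold (0.36 log units) apart, within the scatter of two such steps.
The arm change, hydroxycarbamoyl in place of 2-(hydroxycarbamoyl)ethenyl, stays within the scatter on the methoxy compounds as well (a 1.8-fold higher number from compound 1 to compound 4 (0.26 log units; within the scatter)), and it too carries over: the same change on two cores in this assay, a 1.3-fold lower number (0.11 log units; within the scatter) from compound 2 to compound 3 and a 1.8-fold higher number (0.26 log units; within the scatter) from compound 1 to compound 4, 2.3-fold (0.36 log units) apart, within the scatter of two such steps.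
Each change is thus read only twice, on cores that differ solely in that arm, so the agreement does not show that either step would hold on a core outside these four compounds, and it gives no reason for the size of the bromo to methoxy step.

The compounds shown leave open how chloro or an amine would behave on the same aromatic carbon, and whether a longer chain carrying the hydroxycarbamoyl group would keep the numbers seen here. On these data alone, whether the bromo to methoxy step holds in other cell lines also stays open.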